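The source may hold more compounds than are shown below. What is called first, only, known or untested is meant among the compounds shown, and "the series" means these compounds.

The measured compounds:
Compound 1, `CC(C)N1CCN(Cc2csc(N)c2C(=O)c2ccc(Cl)cc2)CC1`, gives -7.4% in a functional assay on CHO cells with adenosine receptor A1 (Homo sapiens) as the target, read by cAMP accumulation and immunoassay, with a stated time of 6 min, tested at 10 uM; on this read-out lower numbers stand for a stronger effect and higher numbers for a weaker effect at the one concentration tested.
Compound 2, `Nc1scc(CN2CCN(c3cccc(Cl)c3Cl)CC2)c1C(=O)c1ccc(Cl)cc1`, gives -77% in this assay.
Compound 3, `Nc1scc(CN2CCN(c3cccc(C(F)(F)F)c3)CC2)c1C(=O)c1ccc(Cl)cc1`, gives -80% in this assay.

Among these three numbers compound 2 stands second highest. Its nearest neighbour is compound 3, with a number 3 percentage points lower from compound 2 to compound 3 (within the scatter), a gap that the usual scatter swallows, so no order between compound 2 and compound 3 can be read. Its furthest neighbour is compound 1, and the step of a number 69.6 percentage points lower from compound 1 to compound 2 (beyond the scatter) is large.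

Compound 4, `Nc1scc(CN2CCN(c3ccc(F)c(F)c3)CC2)c1C(=O)c1ccc(Cl)cc1`, has not yet been measured. It differs from compound 2 in one place: 3,4-difluorophenyl in place of 2,3-dichlorophenyl on an amine nitrogen in a ring.

Two kinds of measured step bear on this. The large steps of a number 69.6 percentage points lower from compound 1 to compound 2 (beyond the scatter) and a number 72.6 percentage points lower from compound 1 to compound 3 (beyond the scatter) both put an aromatic ring on the ring nitrogen in place of isopropyl. The step from compound 2 to compound 4 keeps an aromatic ring there and only exchanges one substituted phenyl for another, so those two steps describe what was already gained, not what changes now. The closer precedent is a number 3 percentage points lower from compound 2 to compound 3 (within the scatter), also an exchange of one substituted phenyl for another, which lay within the scatter. On that basis no step beyond the scatter is expected from compound 2 to compound 4, in either direction, which means an expected step of a number 2 percentage points higher from compound 2 to compound 4 (within the scatter). Compound 4 is therefore estimated at -75%, in a range from -92% to -55%.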

Compound 4, a percentage reported as activity, at one concentration (the size of the read-out at that concentration, not a potency): -87%
Compound 4: the middle estimate sits 12 percentage points above what was measured, within the range that was stated.
By their numbers in this assay, from the lowest: compounds 4, 3 and 2 (each within the scatter of the next); then compound 1.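

In this assay, a third substituted phenyl group on the ring nitrogen again produces no change that can be read: the exchange gives a number 10 percentage points lower from compound 2 to compound 4 (within the scatter) and, against the trifluoromethyl analogue, a number 7 percentage points lower from compound 3 to compound 4 (within the scatter) in the same comparison, so these three aromatic groups cannot be put in any order. This position therefore accepts fluorine atoms as well as chlorine atoms or a trifluoromethyl group on the phenyl ring without a change beyond the scatter, while the large difference from the isopropyl compound recurs as a number 79.6 percentage points lower from compound 1 to compound 4 (beyond the scatter) and now holds for all three phenyl groups shown. No measurement at hand explains why these phenyl groups behave alike or why they differ from isopropyl.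

The compounds shown leave open whether an unsubstituted phenyl, a methoxyphenyl or a benzyl group on the same nitrogen would give a similar number, and whether a chain longer than isopropyl would close any of the gap. Each number is also the size of the effect at a single concentration, which leaves any difference in potency among the three phenyl compounds unknown.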